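Methyl in place of chloro on compound 2

The source may hold more compounds than are shown below. What is called first, only, known or untested is meant among the compounds shown, and "the series" means these compounds.

In an ADME assay on MT4 cells (Homo sapiens) for cytotoxicity, read by MTT assay, with a stated time of 5 days (a lower number here means that less compound is tolerated, a higher number that more compound is tolerated), compound 1 `N#Cc1ccc(Nc2nccc(C(O)c3ccc(-c4ccc(C#N)cc4)cc3Cl)n2)cc1` gives 7540 nM and compound 2 `N#Cc1ccc(Nc2nccc([C@@H](O)c3ccc(-c4ccc(C#N)cc4)cc3Cl)n2)cc1` gives 4250 nM. Among the measured compounds shown here, the two values lie within the scatter of each other, so compound 2 stands level with the only other measured compound. Compound 3 `Cc1cc(-c2ccc(C#N)cc2)ccc1[C@H](O)c1ccnc(Nc2ccc(C#N)cc2)n1` departs from compound 2 by methyl in place of chloro on an aromatic carbon, with methyl in place of chloro on an aromatic carbon. For the measured compounds named here, the one measured step, a 1.8-fold lower number from compound 1 to compound 2 (0.25 log units; within the scatter), goes with the fact that one of compounds 1 and 2 is drawn with a defined configuration and the other without, at the place where they differ and leaves the chloro untouched. It therefore gives no direct size for this exchange, and in this assay no shift beyond the scatter is expected, with compound 2 at 4250 nM as the anchor. The expected change is a 1.2-fold higher number from compound 2 to compound 3 (0.07 log units; within the scatter). For compound 3 the estimated value is 5000 nM, within an expected range from 2000 nM to 12500 nM.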

Compound 3, half-maximal cytotoxic concentration: 4000 nM
Estimate against measurement, compound 3: 1.3-fold (0.10 log units) above; the measured number falls inside the stated range.
By their numbers in this assay, from the lowest: compounds 3, 2 and 1 (each within the scatter of the next).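

In this assay, methyl in place of chloro on an aromatic carbon, ortho to a large group and meta to a 4-cyanophenyl group, comes to a 1.1-fold lower number from compound 2 to compound 3 (0.03 log units; within the scatter), which leaves the two compounds level. Among the compounds shown here, this is the first direct reading at this position, since the earlier pair kept the chloro and differed only in how a stereo element was drawn. Here the group itself is exchanged, and chloro and methyl at this place cannot be told apart in this read-out. Nothing available bears on why the two groups give values within the scatter of each other.

The compounds shown leave open whether a group of another kind at this aromatic carbon, such as an amine or a carboxylic acid, would stay level with compound 2. The same holds for a longer chain such as propyl.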